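The source may report more compounds than this note shows. Statements on the series, on what has been measured and on what is new or still open speak of the compounds shown alone.

Of the compounds shown here, two have been measured so far in a functional assay on MDA-MB-231 cells (Homo sapiens) for cytotoxicity, read by MTT assay, with a stated time of 48 h; on this read-out lower numbers stand for stronger inhibition and higher numbers for weaker inhibition. Compound 1 (`COc1cc(C2=NOC(COc3ccc(-c4nnnn4-c4cc(OC)c(OC)c(OC)c4)cc3N)C2)cc(OC)c1OC`) gives 3230 nM and compound 2 (`COc1ccc(-c2nnnn2-c2cc(OC)c(OC)c(OC)c2)cc1N`) gives 3170 nM. Among the measured compounds shown here, these two values lie within the scatter of each other, so compound 1 stands level with the only other number available.

The next compound, compound 3 (`COc1cc(-n2nnnc2-c2ccc(OCC3CC(c4ccc(C(F)(F)F)cc4)=NO3)c(N)c2)cc(OC)c1OC`), is made from compound 1 by a single exchange: 4-(trifluoromethyl)phenyl in place of 3,4,5-trimethoxyphenyl on a carbon with a double bond to nitrogen. A 4-(trifluoromethyl)phenyl thus takes the place of the 3,4,5-trimethoxyphenyl on a carbon with a double bond to nitrogen of the five-membered non-aromatic ring.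

For the measured compounds named here, no pair of measured compounds shows what this exchange does. The nearest guide is that compound 2, which lacks this ring and its aryl group, reads 3170 nM, level with compound 1. On that basis, only a small step is expected in this assay, perhaps toward a lower number and perhaps none beyond the scatter. The expected change is a 1.3-fold lower number from compound 1 to compound 3 (0.11 log units; within the scatter). For compound 3 the estimated value is 2500 nM, with an expected range from 800 nM to 8000 nM.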

Compound 3, half-maximal inhibitory concentration: 1750 nM
For compound 3 the middle estimate is 1.4-fold (0.15 log units) above the measured one; low and high end bracket the measured number.
By their numbers in this assay, from the lowest: compounds 3, 2 and 1 (each within the scatter of the next).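

In this assay, among the compounds shown here, putting 4-(trifluoromethyl)phenyl in place of 3,4,5-trimethoxyphenyl on the carbon with a double bond to nitrogen gives a 1.8-fold lower number from compound 1 to compound 3 (0.27 log units; within the scatter), the first step that can be read at this position. For the compounds shown here, the aryl group here can therefore lose its methoxy groups and carry a trifluoromethyl group instead, with no step beyond the scatter, even though the 3 hydrogen-bond acceptors of the group that leaves have no counterpart in the group that enters. Nothing measured here bears on why the two compounds read as they do.

As far as these compounds go, whether any group on this carbon can move the number beyond the scatter stays open, for example an unsubstituted phenyl, a phenyl carrying an amine or a carboxylic acid, or a small alkyl chain in place of the aryl ring. From the compounds shown here alone, all of this rests on a single pair in this assay, so it also remains open whether the same exchange would give a similar step on another version of the core or in other cells.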